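A few compounds are considered here, and "the series" means these few. Any claim that something is new, unique, unknown or untested is made for them only; others in the source may bear on it.

Measured so far in a physicochemical assay for solubility, in the presence of a further agent that is not named here; on this read-out higher numbers stand for higher solubility and lower numbers for lower solubility:
compound 1 `Cc1ccc2c(c1)[n+]([O-])c(NCCN1CCCCC1)n[n+]2[O-]`: 45000000 nM
compound 2 `CC(C)(C)c1ccc2c(c1)[n+]([O-])c(NCCN1CCCCC1)n[n+]2[O-]`: 28000000 nM

Among the compounds with values here, compound 2 is one of only two numbers in this assay, and its sole neighbour, compound 1, sits within the scatter of it. Compound 3 `CCOc1ccc2c(c1)[n+]([O-])c(NCCN1CCCCC1)n[n+]2[O-]` differs from compound 2 by ethoxy in place of tert-butyl on an aromatic carbon. The one step that bears on this position, a 1.6-fold lower number from compound 1 to compound 2 (0.21 log units; within the scatter), stayed within the scatter, so a substituent change at the same aromatic carbon gave no clear shift; whether an ethoxy behaves alike is not shown by any measured pair. For compound 3 no step beyond the scatter is expected, a 1.2-fold higher number from compound 2 to compound 3 (0.07 log units; within the scatter), giving an estimated 33000000 nM with a range from 14000000 nM to 80000000 nM.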

Compound 3, solubility: > 49000000 nM
Compound 3: only a limit was reported; the forecaster's own chance of this, stated with the estimate: 5%; at least 1.4-fold (0.17 log units) between middle value and limit.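

In this assay compound 3 gives only a limit, not a number: the limit of > 49000000 nM in this assay, at which 1 of the 3 values shown sits. Ethoxy in place of tert-butyl on this aromatic carbon gives an at least 1.7-fold higher number from compound 2 to compound 3 (0.24 log units; that floor lies within the scatter) and ethoxy in place of methyl gives an at least 1.0-fold higher number from compound 1 to compound 3 (0.03 log units; that floor lies within the scatter) in the second comparison. The position therefore accepts a group with an oxygen as well as the two alkyl groups, with no fall in the number, though neither floor clears the scatter.

From the compounds shown here alone, how far compound 3 lies past its limit stays open, and with it the true size of both steps. Also open, going by these compounds, is how an amine, a carboxylic acid or a longer alkoxy chain would read on this carbon.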